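The compounds below may be only part of what the source reports. "The series", "measured", "known", "first", "only" and "open" are said of these compounds alone.

Compound 1 `CCCn1ccc2cc(N3CCNCC3)cc(Cl)c2c1=O`: 47%
Compound 2 `CCCn1ccc2cc(-c3ccncc3)cc(Cl)c2c1=O`: 73%
Compound 3 `CCCn1ccc2cc(-c3cccnc3)cc(Cl)c2c1=O`: 83%

In a functional assay on CHO cells for agonist activity at metabotropic glutamate receptor 2 (Homo sapiens), read by GTPgammaS binding (a higher number here means a larger maximal response, a lower number a smaller maximal response), compound 3 has the highest of the three numbers, although the step of a number 10 percentage points higher from compound 2 to compound 3 (within the scatter) is within the scatter, so compound 2 and compound 3 cannot be ranked against each other. Compound 1 stands furthest away, as seen in a number 36 percentage points higher from compound 1 to compound 3 (beyond the scatter).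

Compound 4 `CCCn1ccc2cc(-c3cn[nH]c3)cc(Cl)c2c1=O` is the next variation: 1H-pyrazol-4-yl in place of pyridin-3-yl on an aromatic carbon. The measured steps that bear on this are those in which a pyridinyl ring replaced piperazin-1-yl, a number 26 percentage points higher from compound 1 to compound 2 (beyond the scatter) and a number 36 percentage points higher from compound 1 to compound 3 (beyond the scatter), and the swap between two pyridinyl rings, a number 10 percentage points higher from compound 2 to compound 3 (within the scatter). None of them replaces a six-membered ring with a five-membered one, so the change in compound 4 is only loosely covered. The expected step for compound 4 is small, a number 8 percentage points lower from compound 3 to compound 4 (within the scatter), within the scatter. Compound 4 is therefore estimated at 75%, with a range from 55% to 92%.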

Compound 4, largest response reached (Emax), in percent of the reference or control that the assay uses: 65%
The estimate for compound 4 lay 10 percentage points above the measured number, and the stated range covers the measured number.
By their numbers in this assay, from the lowest: compound 1; then compounds 4, 2 and 3 (each within the scatter of the next, the first and the last beyond it).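

At this place on the shared core, a five-membered aromatic ring still gives a higher number than piperazin-1-yl in this assay (a number 18 percentage points higher from compound 1 to compound 4 (beyond the scatter)), so that gain is not confined to the six-membered pyridinyl rings. Against those rings the picture splits, with pyridin-3-yl clearly ahead (a number 18 percentage points lower from compound 3 to compound 4 (beyond the scatter)) and pyridin-4-yl not separable (a number 8 percentage points lower from compound 2 to compound 4 (within the scatter)). Nothing available explains this difference.

Still open, going by these compounds, is whether a methyl group on the pyrazole nitrogen, in place of its hydrogen, would change the response. On these data alone, a carboxylic acid at this place also remains untested by these compounds.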